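Series notes: benzyl substituent change on compound 1

A few compounds are considered here, and "the series" means these few. Any claim that something is new, unique, unknown or untested is made for them only; others in the source may bear on it.

Compound 1 `C=C(Br)C(=O)Nc1ccc(/C=C2\SC(=O)N(Cc3ccc(C)cc3)C2=O)cc1` is measured in a functional assay on FM3A cells (Mus musculus) for cytotoxicity, read by cell counting, with a stated time of 2 days (a higher number here means a weaker inhibitor, a lower number a stronger inhibitor), at 6100 nM. Among the two numbers known for the series this is the higher one; compound 2 `C=C(Br)C(=O)Nc1cccc(/C=C2\SC(=O)N(Cc3ccc(C)cc3)C2=O)c1` gives 1000 nM in this assay. Compound 3 `Cc1ccc(CN2C(=O)S/C(=C\c3ccc(N)cc3)C2=O)cc1` gives > 250000 nM in this assay, which is a limit of the assay and not a number. The step of an at least 40-fold higher number from compound 1 to compound 3 (1.61 log units; beyond the scatter) rests on the limit of > 250000 nM in this assay, at which 1 of the 3 values shown sits, and concerns the group on the aromatic nitrogen, which compound 4 keeps unchanged.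

Compound 4 `C=C(Br)C(=O)Nc1ccc(/C=C2\SC(=O)N(Cc3cccc(F)c3)C2=O)cc1` differs from compound 1 only in the change (3-fluorophenyl in place of 4-methylphenyl on a saturated chain carbon bound to an amide-type nitrogen in a ring). Within the data shown here, no measured pair alters the group on the saturated chain carbon bound to the amide-type nitrogen in a ring, so the measured steps give no direct guidance for this change. Among the measured compounds shown here, the one measured step, an at least 40-fold higher number from compound 1 to compound 3 (1.61 log units; beyond the scatter), involves a different part of the core and is not taken as a guide here. In the absence of a bearing step, no change beyond the usual scatter is expected for compound 4, and the step of a 1.0-fold lower number from compound 1 to compound 4 (0.01 log units; within the scatter) is set accordingly as an estimate. Compound 4 is therefore estimated at 6000 nM in this assay, with a range from 2000 nM to 20000 nM.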

Compound 4, half-maximal inhibitory concentration: 4000 nM
Estimate against measurement, compound 4: 1.5-fold (0.18 log units) above, and the stated range covers the measured number.
By their numbers in this assay, from the lowest: compound 2; then compounds 4 and 1 (each within the scatter of the next). At a limit, above all of these: compound 3.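

Among these compounds, the first reading at this place, on a saturated chain carbon bound to an amide-type nitrogen in a ring, is in this assay: a 1.5-fold lower number from compound 1 to compound 4 (0.18 log units; within the scatter), so the exchange of 4-methylbenzyl for 3-fluorobenzyl gives compounds 1 and 4 no order in this read-out. With the (1-bromoethenyl)carbonyl group kept on the aromatic nitrogen, this benzyl position therefore accepts this one exchange without a change beyond the scatter, although the step alters both the ring substituent and its location, and the two contributions cannot be separated. Nothing measured here accounts for the step.

Still open, on these data alone, is whether this position stays as undemanding with a different kind of group, such as an amine or a carboxylic acid on the phenyl ring, or a longer chain in place of the benzyl group. Also open is whether 3-fluorobenzyl behaves the same way on the arrangement of compound 2, since the compounds shown pair this exchange only with the arrangement of compound 1.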